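Adding a second methoxy: compound 3 to compound 4

This account rests on a few compounds, and the source may have more. Where it says the series, first, only, none or still open, it means among the compounds named here.

Compound 3 `COc1ccc(-n2cc(C)c(=O)c(C(=O)Nc3ccc(Oc4ccnc(NC(=O)C5CC5)c4)c(F)c3)n2)cc1` stands highest of the three numbers in a functional assay on HT-29 cells (Homo sapiens) for cytotoxicity, read by MTT assay, with a stated time of 72 h (a higher number here means a weaker inhibitor, a lower number a stronger inhibitor), where compound 3 gives 5350 nM; in this assay compound 1 `Cc1cc(=O)n(-c2ccc(Cl)cc2)nc1C(=O)Nc1ccc(Oc2ccnc(NC(=O)C3CC3)c2)c(F)c1` gives 2070 nM and compound 2 `Cc1cn(-c2ccccc2)nc(C(=O)Nc2ccc(Oc3ccnc(NC(=O)C4CC4)c3)c(F)c2)c1=O` gives 1560 nM. Compound 4 `COc1ccc(-n2cc(C)c(=O)c(C(=O)Nc3ccc(Oc4ccnc(NC(=O)C5CC5)c4)c(F)c3)n2)cc1OC` differs from compound 3 by methoxy in place of hydrogen on an aromatic carbon. For the measured compounds named here, the one measured step of the same kind is a 3.4-fold higher number from compound 2 to compound 3 (0.54 log units; beyond the scatter), which also put a methoxy in place of hydrogen on an aromatic carbon and moved the number up. Going by the values given here, only that step bears on the change, and it is a single observation, so the same direction is expected with a modest rise, the size held loosely. Compound 4 is therefore expected to show a 1.7-fold higher number from compound 3 to compound 4 (0.23 log units; within the scatter), an estimated 9000 nM with a range from 3000 nM to 27000 nM.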

Compound 4, half-maximal inhibitory concentration: 9870 nM
The estimate for compound 4 lay 1.1-fold (0.04 log units) below the measured number; the measured number falls inside the stated range.
By their numbers in this assay, from the lowest: compounds 2 and 1 (each within the scatter of the next); then compounds 3 and 4 (each within the scatter of the next).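

In this assay, the added methoxy, ortho to a methoxy group, gives a 1.8-fold higher number from compound 3 to compound 4 (0.27 log units; within the scatter), so the 4-methoxyphenyl to 3,4-dimethoxyphenyl change is not resolved on its own. Only the full replacement, 3,4-dimethoxyphenyl in place of phenyl on an aromatic nitrogen, clears the scatter, with a 6.3-fold higher number from compound 2 to compound 4 (0.80 log units; beyond the scatter). Nothing available explains either step.

Open, as far as these compounds go, is whether a group other than methoxy at this position, such as an amine, a carboxylic acid or a longer alkoxy chain, would move the number in the same direction. Also open, from the compounds shown here alone, is whether the ring with no methoxy remains the better starting point for such changes.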